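Swapping the end group of compound 3

The source may report more compounds than this note shows. Statements on the series, on what has been measured and on what is new or still open speak of the compounds shown alone.

Among the compounds with values here, in a functional assay on HeLa cells (Homo sapiens) for antiproliferative activity, read by MTT assay, with a stated time of 48 h (a higher number here means a weaker inhibitor, a lower number a stronger inhibitor), compound 3 (`COc1cc(CNC(=O)CCCC/C=C/C(C)C)ccc1OCCCCCOc1ccc(C(N)=S)cc1`) reads 46400 nM, the higher of the two exact numbers so far, while compound 1 (`COc1cc(CNC(=O)CCCCCCC(C)C)ccc1OC(=O)CCC(=O)Oc1ccc(-c2cc(=S)ss2)cc1`) reads 5530 nM. Compound 2 (`COc1cc(CNC(=O)CCCC/C=C/C(C)C)ccc1OCCCCOc1ccc(C(N)=S)cc1`) reads > 50000 nM as a limit of the assay, not a number. Compound 4 (`COc1cc(CNC(=O)CCCC/C=C/C(C)C)ccc1OCCCCCOc1ccc(-c2cc(=S)ss2)cc1`) alters compound 3 in one place (a group of 6 heavy atoms (3 carbon, 3 sulfur; one five-membered aromatic ring with 2 hetero atoms) in place of a group of 3 heavy atoms (1 carbon, 1 nitrogen, 1 sulfur; no ring), on an aromatic carbon), putting a group of 6 heavy atoms on an aromatic carbon. Within the data shown here, the only measured step, an at least 1.0-fold lower number from compound 2 to compound 3 (0.03 log units; that floor lies within the scatter), changes a saturated chain, so it says little about this swap. The better guide is compound 1 (5530 nM), which carries the same entering group but differs elsewhere. A move toward stronger inhibition in this assay is therefore expected, estimated as a 3.9-fold lower number from compound 3 to compound 4 (0.59 log units; beyond the scatter) with wide uncertainty. For compound 4 the estimated value is 12000 nM within an expected range of 4000 nM to 35000 nM in this assay (still unmeasured).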

Compound 4, half-maximal inhibitory concentration: > 50000 nM
Compound 4 gave a limit, no number (the forecaster's own chance of this, stated with the estimate: 8%); at least 4.1-fold (0.61 log units) between middle value and limit.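

On this aromatic carbon, para to a large group, the five-membered aromatic ring with 2 hetero atoms brings no gain over the group of 3 heavy atoms it replaces in this assay: the change reads as an at least 1.0-fold higher number from compound 3 to compound 4 (0.03 log units; that floor lies within the scatter). The larger ring, with no hydrogen-bond donor, therefore does not by itself lift this chain-linked compound into a measurable gain. Compound 4 gives a limit, not a number, so the true size of this step stays unknown: the limit of > 50000 nM in this assay, at which 2 of the 4 values shown sit.

As far as these compounds go, whether an amine or a carboxylic acid on this aromatic carbon would read differently remains open. So does the effect of the same ring on a longer chain.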